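The source may hold more compounds than are shown below. What is called first, only, known or untested is meant among the compounds shown, and "the series" means these compounds.

Working notes on the series.

Compound 1 `Cn1c(-c2ccccc2Cl)cs/c1=N\C(=O)c1ccccc1` and compound 2 `Cn1c(-c2cccc(Br)c2)cs/c1=N\C(=O)c1ccccc1` share one core; compound 3 `CN(C(=O)c1ccccc1)c1nc(-c2ccccc2Cl)cs1` and compound 4 `CN(C(=O)c1ccccc1)c1nc(-c2cccc(Br)c2)cs1` share another. Compound 3 and compound 1 are built from the same atoms joined differently, and the difference between the two cores is not broken down here.

In a functional assay on MDA-MB-231 cells (Homo sapiens), read by microscopy and transwell migration, with a stated time of 24 h (a lower number here means a stronger inhibitor, a higher number a weaker inhibitor), compound 1 gives 268 nM, and compound 2 gives 302 nM. The change between them is 3-bromophenyl in place of 2-chlorophenyl on an aromatic carbon, and the step is a 1.1-fold higher number from compound 1 to compound 2 (0.05 log units; within the scatter). Compound 3 gives 41.6 nM in this assay, the lowest number among the three measured compounds, with compound 1 and compound 2 both well beyond the scatter from it.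

Compound 4 is reached from compound 3 by 3-bromophenyl in place of 2-chlorophenyl on an aromatic carbon. This is the same kind of change as that from compound 1 to compound 2, not the same: in compound 1 the place is next to the ring atom that bears a methyl group, whereas in compound 3 it is two ring bonds from the ring atom that bears a large group.

Among the measured compounds shown here, only one measured example of this change exists, on the other core. Resting on compound 1 and compound 2, where the step of a 1.1-fold higher number from compound 1 to compound 2 (0.05 log units; within the scatter) lay within the scatter, the expected step in this assay is a 1.1-fold higher number from compound 3 to compound 4 (0.04 log units; within the scatter). Compound 4 is therefore estimated at 46 nM, with a range from 20 nM to 110 nM.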

Compound 4, half-maximal inhibitory concentration: 437 nM
Beside the measured number, compound 4's estimate is 9.5-fold (0.98 log units) below it; measured number outside the range, above it.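

In this assay the new step, with 3-bromophenyl in place of 2-chlorophenyl on an aromatic carbon, is an 11-fold higher number from compound 3 to compound 4 (1.02 log units; beyond the scatter). The same change therefore gives different results on the two cores: the same change on two cores in this assay, a 1.1-fold higher number (0.05 log units; within the scatter) from compound 1 to compound 2 and an 11-fold higher number (1.02 log units; beyond the scatter) from compound 3 to compound 4, 9.3-fold (0.97 log units) apart, beyond the scatter of two such steps

Among the compounds shown here, this shows that a step read on the core of compound 1 does not carry over to the core of compound 3, so the flat result on the first core gives no guide to the second; it does not show why the cores differ, and it rests on one pair per core, so it supports no general rule about how the two cores respond to other changes.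

The compounds shown leave open whether the loss on the core of compound 3 follows the exchange of chlorine for bromine or the different place of the halogen on the phenyl ring, as these two differences travel together in this change. Also open, on these data alone, is whether the gap between the cores persists with other groups on this aromatic carbon, such as a plain phenyl or a phenyl carrying an amine or a carboxylic acid.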